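Methyl in place of methoxy on the pendant phenyl ring

This account rests on a few compounds, and the source may have more. Where it says the series, first, only, none or still open, it means among the compounds named here.

Measured in a functional assay on Huh-7 cells (Homo sapiens) for inhibition, read by sulforhodamine B assay, with a stated time of 72 h; a higher number here means a weaker inhibitor, a lower number a stronger inhibitor:
compound 1 `COc1ccc2cc(C(C)c3nnc4n3N=C(c3ccc(F)cc3)CS4)ccc2c1` gives 7000 nM
compound 2 `COc1ccc(C2=Nn3c(nnc3C(C)c3ccc4cc(OC)ccc4c3)SC2)cc1` gives 8500 nM

Compound 2 and compound 1 sit within the scatter of each other, the step of a 1.2-fold higher number from compound 1 to compound 2 (0.08 log units; within the scatter) being the only one measured. Compound 3 `COc1ccc2cc(C(C)c3nnc4n3N=C(c3ccc(C)cc3)CS4)ccc2c1` differs from compound 2 by methyl in place of methoxy on an aromatic carbon. Within the data shown here, the one measured step bears on it, since it changes the same aromatic carbon, and it stayed within the scatter. No larger shift is therefore expected for compound 3, an estimated step of a 1.1-fold lower number from compound 2 to compound 3 (0.03 log units; within the scatter). Compound 3 is expected to give about 8000 nM, between 3500 nM and 18000 nM.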

Compound 3, half-maximal inhibitory concentration: 8200 nM
Beside the measured number, compound 3's estimate is 1.0-fold (0.01 log units) below it; low and high end bracket the measured number.
By their numbers in this assay, from the lowest: compounds 1, 3 and 2 (each within the scatter of the next).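

In this assay the change from 4-methoxyphenyl to 4-methylphenyl gives a 1.0-fold lower number from compound 2 to compound 3 (0.02 log units; within the scatter) and the change from fluoro to methyl gives a 1.2-fold higher number from compound 1 to compound 3 (0.07 log units; within the scatter), so the number stays within the scatter across three different groups on this aromatic carbon, where the earlier step compared only two. Nothing measured here explains why these groups read alike. The compounds shown leave open whether an amine, a carboxylic acid or a longer chain on this carbon would shift the number. Changes elsewhere on the shared core also remain open.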